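The source may report more compounds than this note shows. Statements on the series, on what has been measured and on what is new or still open speak of the compounds shown alone.

Compounds measured so far:

Compound 1, `CC1(C)N=C(N)N=C(N)N1c1ccc(OCC(=O)Nc2cccc(S(=O)(=O)F)c2)c(Cl)c1`, in an assay on isolated protein for inhibition of Dihydrofolate reductase (Mus musculus) (a higher number here means a more potent compound, by a factor of ten per unit of this negative logarithm, a lower number a less potent compound), compound 1 gives 7.72.
Compound 2, `CN(C(=O)COc1ccc(N2C(N)=NC(N)=NC2(C)C)cc1Cl)c1ccc(S(=O)(=O)F)cc1`, in this assay compound 2 gives 7.47.
Compound 3, `CC1(C)N=C(N)N=C(N)N1c1ccc(OCC(=O)Nc2ccc(S(=O)(=O)F)cc2)c(Cl)c1`, in this assay compound 3 gives 7.43.

Compound 3 holds the lowest of the three numbers, but both neighbours sit within the scatter of it: the step of a number 0.29 log units lower from compound 1 to compound 3 (within the scatter), and the step of a number 0.04 log units lower from compound 2 to compound 3 (within the scatter). Nothing in these three compounds therefore separates one from another beyond the noise of the measurement.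

Compound 4, `CC(Oc1ccc(N2C(N)=NC(N)=NC2(C)C)cc1Cl)C(=O)Nc1ccc(S(=O)(=O)F)cc1`, has not yet been measured. It differs from compound 3 in one place: methyl in place of hydrogen on a saturated chain carbon bound to a carbonyl carbon and an oxygen on an aromatic ring. Neither of the measured steps touches this chain carbon; one changes the position of the fluorosulfonyl group on the aromatic ring, the other swaps a methyl for hydrogen on the amide-type nitrogen. For the measured compounds named here, both were within the scatter, so the only guidance is that small alterations around the amide linker have so far left this assay unchanged. The step of a number 0.03 log units lower from compound 3 to compound 4 (within the scatter) is accordingly expected to be small, with no direction that can be defended beyond the scatter. For compound 4 the estimate in this assay is 7.4, within a range from 6.9 to 7.9.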

Compound 4, logarithm of the reciprocal of the active concentration, log(1/C): 7.13
Compound 4: the middle estimate sits 0.27 log units above what was measured, and the stated range covers the measured number.
By their numbers in this assay, from the lowest: compounds 4, 3, 2 and 1 (each within the scatter of the next, the first and the last beyond it).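

For the compounds shown here, the chain carbon bound to a carbonyl carbon and an oxygen on an aromatic ring is probed for the first time here, since the earlier steps touched only the amide-type nitrogen and the place of the fluorosulfonyl group. In this assay, methyl in place of hydrogen at this carbon gives a number 0.30 log units lower from compound 3 to compound 4 (within the scatter), so this single added carbon leaves no difference that stands clear of the scatter, although the step lies at the edge of it. Nothing available bears on the reason for this result.

The compounds shown leave open whether this carbon would accept anything larger than methyl, such as an ethyl group, a longer chain or a phenyl ring. They also leave open what a hydroxyl group, an amine or a carboxylic acid would do at the same place.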